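Swapping a Trifluoromethyl for a Methyl on the Amide Ring

The source may hold more compounds than are shown below. What is called first, only, known or untested is meant among the compounds shown, and "the series" means these compounds.

Of the compounds shown here, three sharing one core have been measured in an assay on LtK cells with ATP-sensitive inward rectifier potassium channel 11 (Homo sapiens) as the target; a higher number here means that more compound is needed for the effect, a lower number that less compound is needed. Compound 1 `CC(C)=CC(=O)Nc1c(C(O)(C(F)(F)F)C(F)(F)F)ccc2ccccc12` gives 46 nM. Compound 2 `Cc1cccc(C(=O)Nc2c(C(O)(C(F)(F)F)C(F)(F)F)ccc3ccccc23)c1` gives 23 nM. Compound 3 `O=C(Nc1c(C(O)(C(F)(F)F)C(F)(F)F)ccc2ccccc12)c1cccc(C(F)(F)F)c1` gives 84 nM, the highest of the three numbers; its gap to compound 1 is within the scatter, while a 3.7-fold higher number from compound 2 to compound 3 (0.56 log units; beyond the scatter) is a modest step beyond it.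

Compound 4 `Cc1ccc(C(=O)Nc2c(C(O)(C(F)(F)F)C(F)(F)F)ccc3ccccc23)cc1` is the next variant. The change from compound 3 is 4-methylphenyl in place of 3-(trifluoromethyl)phenyl on a carbonyl carbon. For the measured compounds named here, two measured steps bear on this. First, a 3.7-fold higher number from compound 2 to compound 3 (0.56 log units; beyond the scatter) shows that putting a trifluoromethyl in place of a methyl on the amide ring raised the number, so the opposite exchange should lower it. Second, a 1.8-fold higher number from compound 1 to compound 3 (0.26 log units; within the scatter) and a 2.0-fold lower number from compound 1 to compound 2 (0.30 log units; within the scatter) both lie within the scatter, so the numbers here move in a narrow band. The only difference left is that the methyl of compound 4 sits at a different point on the ring than that of compound 2, for which no comparison exists. A modest downward step, a 3.0-fold lower number from compound 3 to compound 4 (0.48 log units; beyond the scatter), is therefore expected. Compound 4 is estimated at 28 nM, with a likely range from 10 nM to 80 nM.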

Compound 4, half-maximal effective concentration: 76 nM
Beside the measured number, compound 4's estimate is 2.7-fold (0.43 log units) below it, within the range that was stated.
By their numbers in this assay, from the lowest: compounds 2, 1, 4 and 3 (each within the scatter of the next, the first and the last beyond it).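

In this assay, 4-methylphenyl in place of 3-methylphenyl on a carbonyl carbon gives a 3.3-fold higher number from compound 2 to compound 4 (0.52 log units; beyond the scatter) and so shows that this position responds to more than the identity of the group: two methylphenyl groups can be told apart. The other two changes give a 1.1-fold lower number from compound 3 to compound 4 (0.04 log units; within the scatter) and a 1.7-fold higher number from compound 1 to compound 4 (0.22 log units; within the scatter) and place compound 4 level with compound 3 and compound 1, which leaves compound 2 clearly separated from compound 3 and compound 4 only. Nothing available here explains the gap between the two methylphenyl compounds.

The groups shown at this position are all built from carbon, with fluorine in compound 3 alone. Going by these compounds, how a ring carrying an amine or a carboxylic acid would behave in this place remains open.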